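Triazolopyrimidine amines: shortening the hydroxy-bearing amine substituent

The source may hold more compounds than are shown below. What is called first, only, known or untested is meant among the compounds shown, and "the series" means these compounds.

Measured in an assay on isolated protein for binding affinity to adenosine receptor A1 (Bos taurus); a lower number here means a stronger inhibitor, a higher number a weaker inhibitor:
compound 1 `OC1CCC(Nc2nc(-c3ccccc3)nc3c2nnn3Cc2ccccc2F)CC1` gives 1850000 nM
compound 3 `OC1CCC(Nc2nc(-c3ccccc3)nc3c2nnn3Cc2ccccc2)CC1` gives 2700000 nM
compound 2 `c1ccc(Cn2nnc3c(NC4CCCC4)nc(-c4ccccc4)nc32)cc1` gives 11000000 nM

Compound 1 has the lowest number of the three; its gap to compound 3 is a 1.5-fold higher number from compound 1 to compound 3 (0.16 log units; within the scatter), and compound 2 lies further off. As far as these compounds go, compound 4 `OCCNc1nc(-c2ccccc2)nc2c1nnn2Cc1ccccc1F` is untested; from compound 1 it differs by 2-hydroxyethyl in place of 4-hydroxycyclohexyl on a nitrogen on an aromatic ring. Within the data shown here, no measured pair covers exactly this change. Among the measured compounds shown here, the only step at the same position is a 4.1-fold lower number from compound 2 to compound 3 (0.61 log units; beyond the scatter), which shows that this substituent moves this assay modestly. Removing the ring while keeping the hydroxyl is expected to cost somewhat, so for compound 4 a step of a 2.2-fold higher number from compound 1 to compound 4 (0.33 log units; beyond the scatter) is estimated, giving an expected 4000000 nM with a range from 1000000 nM to 15000000 nM.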

Compound 4, inhibition constant: 54000000 nM
Estimate against measurement, compound 4: 14-fold (1.13 log units) below; the measured number lies above the stated range.
By their numbers in this assay, from the lowest: compounds 1 and 3 (each within the scatter of the next); then compound 2; then compound 4.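

In this assay the change from 4-hydroxycyclohexyl to 2-hydroxyethyl on the nitrogen gives a 29-fold higher number from compound 1 to compound 4 (1.47 log units; beyond the scatter) and is the largest step seen at this position, against a 4.1-fold lower number from compound 2 to compound 3 (0.61 log units; beyond the scatter) in the earlier pair. The substituent keeps its hydrogen-bond donor and acceptor counts, so retaining the hydroxyl does not hold the number near that of compound 1. Ring and carbon count are lost together here, and this pair cannot separate them. A 4-hydroxybutyl chain or an unsubstituted cyclohexyl group would help to separate chain length, ring and hydroxyl. Nothing available explains the size of this step.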